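The compounds below may be only part of what the source reports. "The series", "measured", "known", "first", "only" and "open" are said of these compounds alone.

Compound 1 `CC1(C)[C@H]2CC[C@]1(C)N(Cc1cn(-c3cccc(Cl)c3)nn1)C(=O)C2` gives 70 nM in a functional assay on LoVo cells (Homo sapiens) for inhibition, read by MTT assay, with a stated time of 24 h; a higher number here means a weaker inhibitor, a lower number a stronger inhibitor.
Compound 2 `CC1(C)[C@H]2CC[C@]1(C)N(Cc1cn(-c3ccccc3O)nn1)C(=O)C2` gives 540 nM in this assay.
Compound 3 `CC1(C)[C@H]2CC[C@]1(C)N(Cc1cn(-c3ccccc3Br)nn1)C(=O)C2` gives 60 nM in this assay.

Compound 3 has the lowest number of the three, but compound 1 lies within the scatter of it, as a 1.2-fold lower number from compound 1 to compound 3 (0.07 log units; within the scatter) shows, so the two cannot be ranked. Compound 2 stands clearly apart: a 9.0-fold lower number from compound 2 to compound 3 (0.95 log units; beyond the scatter).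

Compound 4 `CC1(C)[C@H]2CC[C@]1(C)N(Cc1cn(-c3ccc(C#N)cc3)nn1)C(=O)C2` has not been measured. It differs from compound 3 in one place: 4-cyanophenyl in place of 2-bromophenyl on an aromatic nitrogen. For the measured compounds named here, two measured steps bear on this. Swapping one halogen-bearing phenyl for another changed little: a 1.2-fold lower number from compound 1 to compound 3 (0.07 log units; within the scatter). Replacing the halogen with a hydroxy, however, gave a modest shift: a 9.0-fold lower number from compound 2 to compound 3 (0.95 log units; beyond the scatter), and the related 7.7-fold higher number from compound 1 to compound 2 (0.89 log units; beyond the scatter). Going by the values given here, no measured compound carries a cyano group, so the step is uncertain; since the entering group brings a hydrogen-bond acceptor, a modest weakening is expected, a 2.5-fold higher number from compound 3 to compound 4 (0.40 log units; beyond the scatter). Compound 4 is therefore estimated at 150 nM, between 50 nM and 450 nM.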

Compound 4, half-maximal inhibitory concentration: 90 nM
Compound 4: middle estimate off by 1.7-fold (0.22 log units), on the high side, and the stated range covers the measured number.
By their numbers in this assay, from the lowest: compounds 3, 1 and 4 (each within the scatter of the next); then compound 2.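

With 4-cyanophenyl on the aromatic nitrogen, the number stays within the scatter of those for both halogen-bearing rings (a 1.5-fold higher number from compound 3 to compound 4 (0.18 log units; within the scatter); a 1.3-fold higher number from compound 1 to compound 4 (0.11 log units; within the scatter)), so among these compounds a low number does not depend on a halogen, and a group carrying a hydrogen-bond acceptor can stand here without a measurable loss. Only 2-hydroxyphenyl now stands apart from the other three rings, and the nitrile-bearing ring keeps a clear gap to it (a 6.0-fold lower number from compound 2 to compound 4 (0.78 log units; beyond the scatter)), although that step changes both the group and its place on the ring. Nothing given here explains why these rings behave as they do.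

Each ring differs in both its group and that group's place, so the two effects remain tangled. An amine or a carboxylic acid on the phenyl ring, or a hydroxy elsewhere on it, remains an open case.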